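Cyano in place of chloro: a solubility estimate

The source may hold more compounds than are shown below. What is called first, only, known or untested is meant among the compounds shown, and "the series" means these compounds.

For the measured compounds named here, in a physicochemical assay for solubility, read by nephelometry, measured as kinetic solubility, at pH 2, tested at 10 mg/mL (a lower number here means a less soluble compound, a higher number a more soluble compound), compound 1 `Cc1ccccc1C(=O)Nc1cc(Cl)ccn1` gives 25 ug/mL and compound 2 `Cc1c(F)cccc1C(=O)Nc1cc(Cl)ccn1` gives 12.5 ug/mL as its reading, so compound 1 cannot be separated from the only other number known. Compound 3 `Cc1ccccc1C(=O)Nc1cc(C#N)ccn1` carries cyano in place of chloro on an aromatic carbon, opposite the ring nitrogen cyano in place of chloro on an aromatic carbon on the core of compound 1. Going by the values given here, the only measured step is a 2.0-fold lower number from compound 1 to compound 2 (0.30 log units; within the scatter) for fluoro in place of hydrogen on an aromatic carbon, a different change that offers weak guidance. No shift beyond the scatter is expected, and the estimated move is no change at the digits printed from compound 1 to compound 3 (within the scatter) on present evidence. Compound 3 is estimated at 25 ug/mL within a range of 8 ug/mL to 75 ug/mL for now.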

Compound 3, solubility: 50 ug/mL
Compound 3: middle estimate off by 2.0-fold (0.30 log units), on the low side; the measured number falls inside the stated range.
By their numbers in this assay, from the lowest: compounds 2, 1 and 3 (each within the scatter of the next, the first and the last beyond it).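

Opposite the ring nitrogen, cyano in place of chloro gives a 2.0-fold higher number from compound 1 to compound 3 (0.30 log units; within the scatter) in this assay. Compound 3 therefore cannot be separated from compound 1, even though cyano brings two heavy atoms and a hydrogen-bond acceptor where chloro had one heavy atom and none. Nothing available accounts for this reading.

As far as these compounds go, whether an amine or a carboxylic acid at this position would give a step beyond the scatter remains open. So does whether cyano in place of chloro would read the same on the core of compound 2.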